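The source may hold more compounds than are shown below. What is called first, only, known or untested is meant among the compounds shown, and "the series" means these compounds.

Working notes on the series around compound 1 `O=C1C(Nc2ccccc2F)=CC(=O)c2c1nc1n2[C@H]2OC[C@@H](O)[C@H]2OC1`. In a functional assay on MCF7 cells (Homo sapiens) for inhibition, read by sulforhodamine B assay (on this read-out higher numbers stand for weaker inhibition and lower numbers for stronger inhibition), compound 1 gives > 4000 nM, which is a limit of the assay rather than a number. Compound 2 `O=C1C=C(Nc2cccc(F)c2)C(=O)c2c1nc1n2[C@H]2OC[C@@H](O)[C@H]2OC1` gives 5500 nM in this assay, and compound 3 `O=C1C=C(Nc2ccc(Br)cc2)C(=O)c2c1nc1n2[C@H]2OC[C@@H](O)[C@H]2OC1` gives 2580 nM. Among the compounds with values here, the one single-point step in hand, a 2.1-fold lower number from compound 2 to compound 3 (0.33 log units; beyond the scatter), concerns a change of the aryl group on the amine nitrogen and says nothing about replacing that aryl amine by a saturated ring. Within the data shown here, compound 1 therefore stands only as the one compound at the limit of > 4000 nM in this assay, at which 1 of the 3 values shown sits, not placed relative to the others beyond that.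

The unmeasured compound 4 `O=C1C(N2CCC2)=CC(=O)c2c1nc1n2[C@H]2OC[C@@H](O)[C@H]2OC1` differs from compound 1 by azetidin-1-yl in place of (2-fluorophenyl)amino on a double-bonded ring carbon. Among the measured compounds shown here, no measured step bears on this change, so no direction can be drawn from the numbers; with compound 1 sitting at a limit, the expected step that the limit leaves unreadable from compound 1 to compound 4 is nominal only and could go either way. Compound 4 is estimated at 5000 nM in this assay, within a wide range from 1500 nM to 15000 nM.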

Compound 4, half-maximal inhibitory concentration: > 16000 nM
Compound 4 ended at the assay's limit; the forecaster's own chance of this, stated with the estimate: 45%; at least 3.2-fold (0.50 log units) between middle value and limit.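

The step from compound 1 to compound 4 cannot be read, as both values are limits of the assay and not numbers. The compounds shown leave open how far azetidin-1-yl and (2-fluorophenyl)amino on this core actually differ in this assay.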